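Fluoro substitution on two cores, one placement

This account rests on a few compounds, and the source may have more. Where it says the series, first, only, none or still open, it means among the compounds named here.

In a functional assay on B16-F10 cells (Mus musculus) for cytotoxicity, read by MTT assay, with a stated time of 48 h (on this read-out lower numbers stand for stronger inhibition and higher numbers for weaker inhibition), the compounds are compared by their half-maximal inhibitory concentration. Compound 1 `S=C(Nc1ccc(Cl)cc1)Nc1nc2ccccc2s1` gives only a limit in this assay, namely > 50000 nM, which is the limit of > 50000 nM in this assay, at which 1 of the 3 values shown sits. Compound 2 `Fc1ccc2nc(NC(=S)Nc3ccc(Cl)cc3)sc2c1` differs from compound 1 by the change (fluoro in place of hydrogen on an aromatic carbon), and in this assay compound 2 gives 48100 nM; the measured step is an at least 1.0-fold lower number from compound 1 to compound 2 (0.01 log units; that floor lies within the scatter). Compound 3 `Clc1cccc2sc(Nc3nc4ccccc4s3)nc12` carries a different core; the difference between the two cores is not broken down here. In this assay compound 3 gives 29500 nM, and this value and that of compound 2 lie within the scatter of one another. Compound 4 `Fc1ccc2nc(Nc3nc4c(Cl)cccc4s3)sc2c1` has not yet been measured. It differs from compound 3 by fluoro in place of hydrogen on an aromatic carbon, the same kind of change as that made from compound 1 to compound 2, at a place described in identical words. The step expected in this assay for compound 4 is a 1.1-fold lower number from compound 3 to compound 4 (0.04 log units; within the scatter). That expectation rests on an at least 1.0-fold lower number from compound 1 to compound 2 (0.01 log units; that floor lies within the scatter), which sits at the floor of the scatter. Compound 4 is therefore estimated at 27000 nM in this assay, with a likely range from 12000 nM to 60000 nM.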

Compound 4, half-maximal inhibitory concentration: > 50000 nM
Compound 4 ended at the assay's limit; the forecaster's own chance of this, stated with the estimate: 20%; middle value at least 1.8-fold (0.26 log units) from the limit.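

Compound 4 gives > 50000 nM in this assay, and this is a limit of the assay and not a number. Read as a step, fluoro in place of hydrogen on an aromatic carbon of this core gives an at least 1.6-fold higher number from compound 3 to compound 4 (0.22 log units; that floor lies within the scatter), so the change brought no measurable gain on this core, though the true size of the step stays unknown. Set beside the earlier step, this does not show that the change acts differently on the two cores, nor does it show that it acts alike on them: the same change on two cores in this assay, an at least 1.0-fold lower number (0.01 log units; that floor lies within the scatter) from compound 1 to compound 2 and an at least 1.6-fold higher number (0.22 log units; that floor lies within the scatter) from compound 3 to compound 4; the limit leaves it open whether they differ.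

The compounds shown leave open how either core would respond to a different group at this place, such as an amine or a carboxylic acid in place of the fluoro. They also leave open how far any weakening could be followed on this read-out, where the values run into a ceiling: the limit of > 50000 nM in this assay, at which 2 of the 4 values shown sit.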